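The compounds below may be only part of what the source reports. "The series", "measured", "known", "first", "only" and "open" are said of these compounds alone.

Working notes on the series. The shared core is that of compound 1 `COCCCCCCCCCCCCCCC/C=C1\CC(CO)(COC(=O)C(C)(C)C)OC1=O`, which in a functional assay on Hs-578T cells (Homo sapiens) for antiproliferative activity (on this read-out higher numbers stand for weaker inhibition of growth and lower numbers for stronger inhibition of growth), gives 5.45 ug/mL. Compound 2 `CC(=O)OCCCCCCCCCCCCCCC/C=C1\CC(CO)(COC(=O)C(C)(C)C)OC1=O` carries an acetyl in place of methyl on an oxygen on a saturated carbon. In this assay compound 2 reaches only the limit of > 10 ug/mL, a limit and not a number. Compound 3 `CCCCCCCCC(O)CCCCCC/C=C1\CC(CO)(COC(=O)C(C)(C)C)OC1=O` likewise reports only the limit of > 10 ug/mL in this assay. The two measured steps read an at least 1.8-fold higher number from compound 1 to compound 2 (0.26 log units; that floor lies within the scatter) and an at least 1.8-fold higher number from compound 1 to compound 3 (0.26 log units; that floor lies within the scatter); both are floors set by the limit of > 10 ug/mL in this assay, at which 2 of the 3 values shown sit. Compound 2 therefore stands at that limit, together with one further value of the three.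

Compound 4 `COC(=O)CCCCCCCCCCCCCC/C=C1\CC(CO)(COC(=O)C(C)(C)C)OC1=O` differs from compound 2 by methoxycarbonyl in place of acetoxymethyl on a saturated chain carbon, ten or more bonds along the chain from a double-bonded chain carbon. The step from compound 1 to compound 2 bears on this most closely: it placed the acetoxymethyl that now leaves, and it is only a floor that lies within the scatter. The step from compound 1 to compound 3 touched the chain at a different place and is also only a floor. No movement beyond the scatter is therefore expected in this assay. Compound 4 is estimated at 10 ug/mL, between 4 ug/mL and 25 ug/mL. This means an expected step of a number no higher from compound 2 to compound 4 (the limit leaves the size open), with a fair chance that the assay again reports only a limit.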

Compound 4, concentration for 50% growth inhibition: > 10 ug/mL
Compound 4: a limit, no number (the forecaster's own chance of this, stated with the estimate: 55%); the middle value lies on the limit itself.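

In this assay compound 4 also gives only a limit, > 10 ug/mL, so methoxycarbonyl at this position yields no number, just as acetoxymethyl did. Methoxycarbonyl in place of methoxymethyl gives an at least 1.8-fold higher number from compound 1 to compound 4 (0.26 log units; that floor lies within the scatter), a second floor for a change at this position, and it does not show a real loss of growth inhibition. The step between the two limit values cannot be read, so acetoxymethyl and methoxycarbonyl cannot be ranked, and the series now offers few numbers to compare: the limit of > 10 ug/mL in this assay, at which 3 of the 4 values shown sit.

As far as these compounds go, whether either group truly differs from the methoxymethyl of compound 1, which gives 5.45 ug/mL, remains open while these floors lie within the scatter. Also open, from the compounds shown here alone, is what a carboxylic acid, a primary amine or a longer chain would give at this position in this assay.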